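Swapping a branched chain for phenyl: stability outlook

A few compounds are considered here, and "the series" means these few. Any claim that something is new, unique, unknown or untested is made for them only; others in the source may bear on it.

Compound 1, `CC(C)[C@@H](C[C@H]1SC(=O)NC1=O)c1ccc(-c2ccc3cccc(F)c3c2)[nH]c1=O`: 0.77 h
Compound 2, `C/C(=C1/OC(=O)NC1=O)C(c1ccc(-c2ccc3cccc(F)c3c2)[nH]c1=O)C(C)C`: > 3 h
Compound 3, `CCC(CC)C(/C=C1\OC(=O)NC1=O)c1ccc(-c2ccc3cccc(F)c3c2)[nH]c1=O`: > 3 h

Of the compounds shown here, three have been measured in an ADME assay on microsomes from liver (Rattus norvegicus) for metabolic stability; a lower number here means that the compound disappears faster, a higher number that the compound lasts longer. Compound 1 gives 0.77 h in this assay. For compound 2 the reading of > 3 h is a limit of the assay, not a number. For compound 3 the reading of > 3 h is likewise a limit. Compound 3 therefore stands at the upper edge of what the assay reports, (the limit of > 3 h in this assay, at which 2 of the 3 values shown sit), while compound 1 sits well inside the measurable range. Among the measured compounds shown here, no two of the measured compounds differ in only one place, so no single measured step can be drawn from them.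

Compound 4, `O=C1NC(=O)/C(=C/C(c2ccccc2)c2ccc(-c3ccc4cccc(F)c4c3)[nH]c2=O)O1`, is yet to be measured. It differs from compound 3 in one place: phenyl in place of pentan-3-yl on a saturated chain carbon bound to an aromatic carbon and a double-bonded chain carbon. The rest of compound 3, including its core and its double-bonded chain carbon, stays unchanged in compound 4.

Since both compound 2 and compound 3 reached the limit in this assay, compound 4 is expected to stay long-lived as well, with a step of a number no higher from compound 3 to compound 4 (the limit leaves the size open) that should be no larger than the usual scatter. Compound 4 is thus estimated at 3 h, within a range from 1.2 h to 6 h.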

Compound 4, half-life: > 3 h
Compound 4: no number, only a limit (the forecaster's own chance of this, stated with the estimate: 55%); the middle value lies on the limit itself.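

Compound 3 and compound 4 both give a limit rather than a number in this assay, so phenyl in place of pentan-3-yl yields no readable step between them: the limit of > 3 h in this assay, at which 3 of the 4 values shown sit. The compounds shown leave open how long compound 3 and compound 4 really last, and whether this swap alters that at all.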